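A Small Extension on the Amide-Type Nitrogen

The source may report more compounds than this note shows. Statements on the series, on what has been measured and on what is new or still open speak of the compounds shown alone.

In a functional assay on RPMI-8226 cells (Homo sapiens) for cytotoxicity, read by MTT assay, with a stated time of 72 h (a higher number here means a weaker inhibitor, a lower number a stronger inhibitor), compound 2 `Cc1c(C)c2c(c(C)c1OC(=O)CCC(=O)NC1CC(C)(C)N([O])C1(C)C)CC[C@@](C)(CCC[C@H](C)CCC[C@H](C)CCCC(C)C)O2` gives 55000 nM. Within the data shown here, compound 3 `Cc1c(C)c2c(c(C)c1OC(=O)CCC(=O)O)CCC(C)(C(=O)O)O2` gives 63000 nM, so these two stand level within the scatter and hold the only exact numbers so far. Compound 1 `Cc1c(C)c2c(c(C)c1OC(=O)CCC(=O)NC1CC(C)(C)N([O])C(C)(C)C1)CC[C@@](C)(CCC[C@H](C)CCC[C@H](C)CCCC(C)C)O2` gives only a limit, > 300000 nM.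

Compound 4 `Cc1c(C)c2c(c(C)c1OC(=O)CCC(=O)NCC1CC(C)(C)N([O])C1(C)C)CC[C@@](C)(CCC[C@H](C)CCC[C@H](C)CCCC(C)C)O2` has not yet been measured. It departs from compound 2 on the amide-type nitrogen: a group of 11 heavy atoms (9 carbon, 1 nitrogen, 1 oxygen; one five-membered non-aromatic ring with 1 hetero atom) in place of a group of 10 heavy atoms (8 carbon, 1 nitrogen, 1 oxygen; one five-membered non-aromatic ring with 1 hetero atom), on an amide-type nitrogen. The five-membered non-aromatic ring remains, while the group grows. Among the measured compounds shown here, one measured step bears on this change: an at least 5.4-fold lower number from compound 1 to compound 2 (0.73 log units; beyond the scatter). There, a group of 10 heavy atoms with a five-membered non-aromatic ring took the place of a group of 11 heavy atoms with a six-membered non-aromatic ring. That step lies beyond the scatter, but it changed both ring and group size, so it is only a loose guide here. The group of compound 4 resembles that of compound 1 in its number of heavy atoms and that of compound 2 in its ring. Given that mixed picture, only a modest shift toward a higher number is expected, an estimated 1.3-fold higher number from compound 2 to compound 4 (0.10 log units; within the scatter). For compound 4 the expected value in this assay is 70000 nM, with an estimated range from 25000 nM to 250000 nM.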

Compound 4, half-maximal inhibitory concentration: 217000 nM
Beside the measured number, compound 4's estimate is 3.1-fold (0.49 log units) below it, within the range that was stated.
By their numbers in this assay, from the lowest: compounds 2 and 3 (each within the scatter of the next); then compound 4. At a limit, above all of these: compound 1.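

In this assay, the group on the amide-type nitrogen proved sensitive even with its five-membered non-aromatic ring kept, with a 3.9-fold higher number from compound 2 to compound 4 (0.60 log units; beyond the scatter) when the group of 11 heavy atoms took the place of the group of 10 heavy atoms. The earlier step, an at least 5.4-fold lower number from compound 1 to compound 2 (0.73 log units; beyond the scatter), had changed ring and group size together, whereas this pair keeps the ring type and so ties a shift beyond the scatter to a change in the group with that ring retained. Compound 1 holds only a limit, and with the same count of heavy atoms in both groups the change of ring gives an at least 1.3-fold lower number from compound 1 to compound 4 (0.14 log units; that floor lies within the scatter), which does not separate the two rings: the limit of > 300000 nM in this assay, at which 1 of the 4 values shown sits.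

The compounds shown leave open whether a longer chain in this group would carry the number further in the same direction, or whether an amine or a carboxylic acid on the ring would change the picture. They also do not tell whether the shift belongs to the added heavy atom itself or to the way the ring is now attached to the amide-type nitrogen.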